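Vinyl to propyl on the shared core of compound 1

The source may hold more compounds than are shown below. What is called first, only, known or untested is meant among the compounds shown, and "the series" means these compounds.

Measured so far in an ADME assay on L1210/0 cells (Mus musculus) for cytotoxicity, with a stated time of 48 h; a lower number here means a stronger inhibitor, a higher number a weaker inhibitor:
compound 1 `C=Cc1cn([C@H]2C[C@H](O)[C@@H](CO)O2)c(=O)[nH]c1=O` — 14200 nM
compound 2 `C[C@H](O)C1CC(CCn2nnc3c(N)ncnc32)C1(C)C` — > 200000 nM

For the measured compounds named here, compound 1 is the only compound with a real number in this assay; the one other value shown is a limit rather than a number. For compound 2 this assay reports only a limit, and compound 2 sits at the limit of > 200000 nM in this assay, at which 1 of the 2 values shown sits. Going by the values given here, no step between two measured compounds that differ in a single place is available, so there is no measured step to lean on.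

Compound 3 `CCCc1cn([C@H]2C[C@H](O)[C@@H](CO)O2)c(=O)[nH]c1=O` has not yet been measured in this assay. It differs from compound 1 in one place: propyl in place of vinyl on an aromatic carbon. Among the compounds with values here, the change keeps the heavy-atom count close and removes the double bond outside aromatic rings, and nothing among the measured compounds tells how this assay answers such a change.

The expected step is a 3.5-fold higher number from compound 1 to compound 3 (0.55 log units; beyond the scatter), a weakening that is likely to sit a little beyond the usual scatter rather than within it. Compound 3 is estimated at 50000 nM, with a range from 15000 nM to 180000 nM.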

Compound 3, half-maximal inhibitory concentration: > 200000 nM
Compound 3 gave a limit, no number (the forecaster's own chance of this, stated with the estimate: 25%); middle value at least 4.0-fold (0.60 log units) away from the limit.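

In this assay, this aromatic carbon, two atoms from the ring nitrogen, now has its first measured step: an at least 14-fold higher number from compound 1 to compound 3 (1.14 log units; beyond the scatter). For the compounds shown here, the position therefore responds strongly to this change, which the earlier compounds could not show, as compound 2 differs from compound 1 in more than one place and offers no comparison. Compound 3 gives a limit and not a number, so the step sets only a minimum size, and compound 3 now shares that limit with compound 2: the limit of > 200000 nM in this assay, at which 2 of the 3 values shown sit.

The pair leaves open whether the loss of the double bond outside aromatic rings or the longer chain drives the step, since propyl in place of vinyl changes both at once. An ethyl group on this carbon would separate the two, and an ethynyl group or a halogen such as bromine would show whether any other small group can match the number of compound 1 in this assay.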